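The compounds below may be only part of what the source reports. "The series", "measured", "known", "first", "only" and "open" are said of these compounds alone.

Compound 1, `C=C1C[C@]23C[C@@]1(O)CC[C@H]2c1ccc(OS(=O)(=O)c2ccc(C)cc2)c(C)c1[C@@H]3Cn1cc(-c2ccc(Br)cc2)nn1`, is one of three close relatives examined in a functional assay on SW480 cells (Homo sapiens) for cytotoxicity, read by MTT assay, with a stated time of 4 days; a lower number here means a stronger inhibitor, a higher number a weaker inhibitor. In this assay compound 1 gives > 20000 nM, which is a limit of the assay rather than a number. Compound 2, `C=C1C[C@]23C[C@@]1(O)CC[C@@H]2c1cccc(C)c1[C@@H]3Cn1cc(-c2ccc(Br)cc2)nn1`, gives > 20000 nM in this assay, again only a limit. Compound 3, `C=C1C[C@]23C[C@@]1(O)CC[C@H]2c1cc(Br)c(O)c(C)c1[C@@H]3Cn1cc(-c2ccccn2)nn1`, gives > 20000 nM in this assay, also a limit. Everything known so far therefore rests at the limit of > 20000 nM in this assay, at which 3 of the 3 values shown sit, so compound 1 cannot be placed above or below its two neighbours; no number separates any of them.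

Compound 4, `C=C1C[C@]23C[C@@]1(O)CC[C@H]2c1ccc(OS(=O)(=O)c2ccc(C)cc2)c(C)c1[C@@H]3Cn1cc(-c2ccccc2)nn1`, is compound 1 with a single change: hydrogen in place of bromo on an aromatic carbon. Among the compounds with values here, no step between measured compounds exists to lean on, and the shared core has given no numerical reading in any of the three cases. The step that the limit leaves unreadable from compound 1 to compound 4 is expected to be none beyond the scatter, because the limit of > 20000 nM in this assay, at which 3 of the 3 values shown sit, is where every measured relative sits. Compound 4 is thus expected to give about 30000 nM in this assay, between 15000 nM and 100000 nM, and most probably only as a limit once more.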

Compound 4, half-maximal inhibitory concentration: > 20000 nM
Compound 4: no number, only a limit (the forecaster's own chance of this, stated with the estimate: 85%); the middle value does not contradict the limit.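

In this assay, within the data shown here, compound 1 and compound 4 each stand only as a limit, and no step from bromo to hydrogen can be read between them. The compounds shown leave open what number any of them would give, and which change to the shared core, if any, would yield a reading.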